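The compounds below may be only part of what the source reports. "The series", "measured", "known", "first", "only" and "open" are said of these compounds alone.

Compound 1 `O=C(Nc1cc(-c2ccccc2)nn1-c1ccccc1)c1ccccc1` gives 203 nM in a functional assay on cells for positive allosteric modulation of metabotropic glutamate receptor 5 (Rattus norvegicus), read by calcium flux; a lower number here means that less compound is needed, a higher number that more compound is needed for the effect.
Compound 2 `O=C(Nc1cc(-c2ccccc2)nn1-c1ccccc1)c1cccc(C(F)(F)F)c1` gives 228 nM in this assay.
Compound 3 `O=C(Nc1cc(-c2ccccc2)nn1-c1ccccc1)C1CCCCC1` reaches only a limit of this assay, > 10000 nM.

Compound 3 therefore stands at the limit (the limit of > 10000 nM in this assay, at which 1 of the 3 values shown sits), with no number of its own. The steps of an at least 49-fold higher number from compound 1 to compound 3 (1.69 log units; beyond the scatter) and an at least 43-fold higher number from compound 2 to compound 3 (1.64 log units; beyond the scatter) are both large and both lead to this limit. Compound 4 `O=C(Nc1cc(-c2ccccc2)nn1-c1ccccc1)C1CCCC1` differs from compound 3 only by cyclopentyl in place of cyclohexyl on a carbonyl carbon. Among the compounds with values here, no measured step bears on this ring-size change; the two steps into compound 3 show only that a saturated ring at this place lies beyond the measurable range. Compound 4 is therefore expected to stay near that limit, with the step of a number no higher from compound 3 to compound 4 (the limit leaves the size open) estimated as small. The estimate for compound 4 in this assay is 10000 nM, with a range from 3000 nM to 30000 nM.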

Compound 4, half-maximal effective concentration: 3410 nM
Compound 4: the middle estimate sits 2.9-fold (0.47 log units) above what was measured, within the range that was stated.
By their numbers in this assay, from the lowest: compounds 1 and 2 (each within the scatter of the next); then compound 4. At a limit, above all of these: compound 3.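

In this assay, a saturated ring on the carbonyl carbon does not always lie beyond the measurable range: the change to cyclopentyl gives an at least 2.9-fold lower number from compound 3 to compound 4 (0.46 log units; beyond the scatter). Cyclopentyl still falls well short of the aromatic rings at this place, with a 17-fold higher number from compound 1 to compound 4 (1.23 log units; beyond the scatter) and a 15-fold higher number from compound 2 to compound 4 (1.17 log units; beyond the scatter). The value of compound 3 is a limit, so the full size of the ring-size step cannot be read: the limit of > 10000 nM in this assay, at which 1 of the 4 values shown sits.

As far as these compounds go, whether cyclobutyl or cyclopropyl on this carbonyl carbon would continue the shift seen with the smaller ring remains open. So does whether a pyridine ring here would keep the value of compound 1.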